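This account rests on a few compounds, and the source may have more. Where it says the series, first, only, none or still open, it means among the compounds named here.

Compound 1 `N#C/C(=C\c1ccc(Cl)cc1)C(=O)c1ccc[nH]1`: 43000 nM
Compound 2 `N#C/C(=C\c1ccc([N+](=O)[O-])cc1)C(=O)c1c[nH]c2ccccc12`: 47000 nM
Compound 3 `N#C/C(=C\c1ccc[nH]1)C(=O)NCc1ccc(Cl)c(Cl)c1`: > 50000 nM

In a functional assay on NCI-H460 cells (Homo sapiens) for inhibition, read by MTT assay, with a stated time of 72 h (on this read-out higher numbers stand for weaker inhibition of growth and lower numbers for stronger inhibition of growth), compound 1 gives 43000 nM and compound 2 gives 47000 nM. For compound 3 this assay reports only a limit, > 50000 nM, and not a number. This is where compound 3 stands among the values shown: the limit of > 50000 nM in this assay, at which 1 of the 3 values shown sits, while the other two compounds sit at numbers below that limit.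

Compound 4 `N#C/C(=C\c1ccco1)C(=O)NCc1ccc(Cl)c(Cl)c1` differs from compound 3 in one place: furan-2-yl in place of 1H-pyrrol-2-yl on a double-bonded chain carbon bound to a double-bonded chain carbon. For the measured compounds named here, no measured pair shows what exchanging these two five-membered rings does in this assay, so the size of the step cannot be read from the data. Given that compound 3 sits at the limit in this assay, the change is expected to leave compound 4 in the same region, with no step beyond the scatter in either direction. The step of a number no higher from compound 3 to compound 4 (the limit leaves the size open) is therefore expected to be small. Compound 4 is estimated to give about 50000 nM in this assay, within a range from 20000 nM to 120000 nM.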

Compound 4, concentration for 50% growth inhibition: > 50000 nM
Compound 4: a limit, no number; the forecaster's own chance of this, stated with the estimate: 65%; the middle value lies on the limit itself.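

In this assay, for the compounds shown here, compound 4 gives > 50000 nM, a limit and not a number, as compound 3 also has, so no step between compound 3 and compound 4 can be read: the limit of > 50000 nM in this assay, at which 2 of the 4 values shown sit. The compounds shown leave open what exchanging 1H-pyrrol-2-yl for furan-2-yl does to growth inhibition in this assay.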